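The compounds below may be only part of what the source reports. "The series", "measured", "known", "first", "only" and "open" are said of these compounds alone.

Going by the values given here, compound 3 `COC(=O)C(=O)NC1=C(C#N)C2C(N3CCCC3)CCCCN2C(=O)N1c1ccccc1` stands at the top of the three numbers so far, with 85.6% in a functional assay on the whole organism (strain albino) for inhibition, with Rattus norvegicus as the target, read by paw edema, with stated times of 1 h and 2 h, at a dose of 20 mmol/kg by the intraperitoneal route; a higher number here means more inhibition at the dose given (going by the name of the read-out), a lower number less inhibition; compound 1 `CCOC(=O)C(=O)NC1=C(C#N)C2C(N3CCCC3)CCCCN2C(=O)N1c1ccccc1` gives 83.6% and compound 2 `N#CC1=C(/N=C/c2ccc([N+](=O)[O-])cc2)N(c2ccccc2)C(=O)N2CCCCC(N3CCCC3)C12` gives 80.9%, both within the scatter of compound 3. Compound 4 `N#CC1=C(NC(=O)c2ccccc2O)N(c2ccccc2)C(=O)N2CCCCC(N3CCCC3)C12` differs from compound 3 by 2-hydroxyphenyl in place of methoxycarbonyl on a carbonyl carbon. The steps that bear on this change are the small ones already seen at the same region: a number 2 percentage points higher from compound 1 to compound 3 (within the scatter) and a number 4.7 percentage points higher from compound 2 to compound 3 (within the scatter), neither beyond the scatter, which suggests the substituent on the double-bonded ring carbon has changed the read-out little among these three. A step of a number 4.6 percentage points lower from compound 3 to compound 4 (within the scatter) is therefore expected, that is none beyond the scatter. The estimate for compound 4 in this assay is 81%, in the range 70% to 91%.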

Compound 4, a percentage reported as inhibition, in the whole organism at one dose (the size of the read-out at that dose, not a potency): 53.8%
Estimate against measurement, compound 4: 27.2 percentage points above; measured number outside the range, below it.
By their numbers in this assay, from the lowest: compound 4; then compounds 2, 1 and 3 (each within the scatter of the next).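

In this assay, the substituent region that had looked insensitive among the first three compounds proves sensitive: the carbonyl carbon carrying 2-hydroxyphenyl in place of methoxycarbonyl gives a number 31.8 percentage points lower from compound 3 to compound 4 (beyond the scatter) beyond the scatter. The same holds against ethoxycarbonyl, with a number 29.8 percentage points lower from compound 1 to compound 4 (beyond the scatter) as the step, and against the group of compound 2, with a number 27.1 percentage points lower from compound 2 to compound 4 (beyond the scatter) as the step, so compound 4 alone separates from the other three. Nothing measured here accounts for this loss of inhibition.

The compounds shown do not separate the contribution of the aromatic ring from that of its hydroxyl, which a plain phenyl on this carbonyl carbon would address. As far as these compounds go, how a free carboxylic acid or a simple amide at this place would read also stays open.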